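Urea to amide swap on two pyrrolopyridine cores

The source may report more compounds than this note shows. Statements on the series, on what has been measured and on what is new or still open speak of the compounds shown alone.

Measured so far in a functional assay on A375P cells (Homo sapiens) for cytotoxicity, read by MTT assay; a lower number here means a stronger inhibitor, a higher number a weaker inhibitor:
compound 1 `COC(=O)c1ccc2c(ccn2-c2cccc(NC(=O)Nc3cccc(C(F)(F)F)c3)c2)n1`, > 10000 nM
compound 2 `O=C(Nc1ccc(-n2ccc3nc(C(=O)NCc4ccccc4)ccc32)cc1)Nc1cccc(C(F)(F)F)c1`, 7900 nM
compound 3 `O=C(Nc1ccc(-n2ccc3nc(C(=O)NCc4ccccc4)ccc32)cc1)c1ccc(Cl)c(C(F)(F)F)c1`, 700 nM

The value of compound 1 is a limit of the assay, not a number; it sits at the limit of > 10000 nM in this assay, at which 1 of the 3 values shown sits. Compound 2 and compound 3 share one core and differ by 4-chloro-3-(trifluoromethyl)phenyl in place of (3-(trifluoromethyl)phenyl)amino on a carbonyl carbon; this gives an 11-fold lower number from compound 2 to compound 3 (1.05 log units; beyond the scatter). How the core of compound 1 differs from that of compound 2 is not broken down here.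

Compound 4 `COC(=O)c1ccc2c(ccn2-c2cccc(NC(=O)c3ccc(Cl)c(C(F)(F)F)c3)c2)n1` is not yet measured; it differs from compound 1 by 4-chloro-3-(trifluoromethyl)phenyl in place of (3-(trifluoromethyl)phenyl)amino on a carbonyl carbon, the same change as from compound 2 to compound 3. For compound 4 the expected step is an at least 3.3-fold lower number from compound 1 to compound 4 (0.52 log units; beyond the scatter), resting on the step from compound 2 to compound 3 of an 11-fold lower number from compound 2 to compound 3 (1.05 log units; beyond the scatter). Since compound 1 gives only a limit, the expected value for compound 4 is uncertain and is estimated as 3000 nM, between 800 nM and 15000 nM.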

Compound 4, half-maximal inhibitory concentration: > 10000 nM
Compound 4: only a limit was reported (the forecaster's own chance of this, stated with the estimate: 35%); middle value at least 3.3-fold (0.52 log units) away from the limit.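

Compound 1 and compound 4 both sit at a limit of this assay, not at a number, so no step between them can be read: the limit of > 10000 nM in this assay, at which 2 of the 4 values shown sit.

On these data alone, whether the change seen between compound 2 and compound 3 lowers the number on the core of compound 1 stays open.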